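Bromo in place of chloro: compound 2 to compound 3

The source may hold more compounds than are shown below. What is called first, only, known or untested is meant among the compounds shown, and "the series" means these compounds.

In a functional assay on MOLT-4 cells (Homo sapiens) for inhibition, read by MTT assay, with a stated time of 72 h (a higher number here means a weaker inhibitor, a lower number a stronger inhibitor), compound 1 `COc1cc(NC(C)CCCNC(=O)Nc2cccc(F)c2)c2ncccc2c1` gives 23000 nM, while compound 2 `COc1cc(NC(C)CCCNC(=O)NNC(=O)Nc2ccc(Cl)cc2)c2ncccc2c1` gives 186000 nM, the highest of the two numbers. Compound 3 `COc1cc(NC(C)CCCNC(=O)NNC(=O)Nc2ccc(Br)cc2)c2ncccc2c1` departs from compound 2 by one exchange: bromo in place of chloro on an aromatic carbon. Among the compounds with values here, the only measured step, an 8.1-fold higher number from compound 1 to compound 2 (0.91 log units; beyond the scatter), is modest and replaces a much larger piece of the structure, so it bears only weakly here. No shift beyond the scatter is therefore expected in this assay. The expected step is a 1.1-fold lower number from compound 2 to compound 3 (0.04 log units; within the scatter). Compound 3 is estimated at 170000 nM, with an expected range of 90000 nM to 320000 nM.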

Compound 3, half-maximal inhibitory concentration: 209000 nM
Compound 3: the middle estimate sits 1.2-fold (0.09 log units) below what was measured, within the range that was stated.
By their numbers in this assay, from the lowest: compound 1; then compounds 2 and 3 (each within the scatter of the next).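

In this assay, bromo in place of chloro on an aromatic carbon para to a large group gives a 1.1-fold higher number from compound 2 to compound 3 (0.05 log units; within the scatter), so this exchange does not separate the two compounds. The larger replacement, ((4-bromophenyl)carbamoyl)amino in place of 3-fluorophenyl, gives a 9.1-fold higher number from compound 1 to compound 3 (0.96 log units; beyond the scatter), so its step beyond the scatter holds with bromo as with chloro. Nothing available accounts for either step.

Still open, as far as these compounds go, is whether a group other than a halogen, such as methoxy, nitrile or an amine, would shift the number at this place. From the compounds shown here alone, the effect of a longer chain on the same series also remains open.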